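Removing an Acetoxy Group from a Very Short-Lived Ester

The source may hold more compounds than are shown below. What is called first, only, known or untested is meant among the compounds shown, and "the series" means these compounds.

Of the compounds shown here, three have been tested in an ADME assay on a cell-free system (plasma, Homo sapiens) for metabolic stability; on this read-out higher numbers stand for a longer-lived compound and lower numbers for a shorter-lived compound. Compound 1 `CCCC(CCC)C(=O)OCN(CC(=O)OCC)C(=O)c1ccccc1` gives 22 h, and compound 3 `CCN(CC)CC(=O)N(COC(=O)C(C)(C)C)c1c(C)cccc1C` gives 4.67 h. Compound 2 `CCOC(=O)c1ccc(/N=N/N(C)C(=O)OCOC(=O)c2ccccc2OC(C)=O)cc1` gives 0.0167 h, the lowest of the three numbers by a wide margin: its nearest neighbour in this assay is compound 3, far beyond the usual scatter, and compound 1 lies further still. Compound 4 `CCOC(=O)c1ccc(/N=N/N(C)C(=O)OCOC(=O)c2ccccc2)cc1` has not yet been measured in this assay. It differs from compound 2 in one place: hydrogen in place of acetoxy on an aromatic carbon. Among the measured compounds shown here, both compounds that carry no acetoxy group, compound 1 and compound 3, show markedly longer half-lives than compound 2, and no compound among the three goes against this. On that basis, compound 4 is expected to last longer than compound 2, with an estimated step of a 15-fold higher number from compound 2 to compound 4 (1.18 log units; beyond the scatter), well beyond the scatter. The half-life of compound 4 in this assay is estimated at 0.25 h, with a range from 0.04 h to 1.5 h.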

Compound 4, half-life: 0.783 h
The estimate for compound 4 lay 3.1-fold (0.50 log units) below the measured number, within the range that was stated.
By their numbers in this assay, from the lowest: compound 2; then compound 4; then compound 3; then compound 1.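

In this assay, replacing acetoxy with hydrogen on an aromatic carbon ortho to a large group gives a 47-fold higher number from compound 2 to compound 4 (1.67 log units; beyond the scatter) and is a large change, beyond the usual scatter. The earlier compounds shown here differ from one another in many places, so they could not tie any part of their spread to a single group; this pair ties a large difference to this one position and this one change. Nothing available here explains why the half-life responds so strongly to this change.

On these data alone, the pair compares only acetoxy and hydrogen, so it remains open where a hydroxyl, a methoxy or an amine on the same carbon would fall. As far as these compounds go, it also remains open whether 2-acetoxyphenyl to phenyl would bring a similar step on a different core.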